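This account rests on a few compounds, and the source may have more. Where it says the series, first, only, none or still open, it means among the compounds named here.

Measured compounds in an ADME assay on microsomes from liver (Homo sapiens) for metabolic stability; on this read-out higher numbers stand for a longer-lived compound and lower numbers for a shorter-lived compound:
Compound 1 `CCn1ncc2c(F)cc(-c3ccc(C(CC)(CC)c4nnc[nH]4)c(=O)[nH]3)cc21` gives 2.7 h.
Compound 2 `CCn1ncc2c(F)cc(-c3ccc(C(CC)(CC)c4nnc(C)[nH]4)c(=O)[nH]3)cc21` gives > 3 h, a limit of the assay rather than a number.
Compound 3 `CC(C)C(c1cnc(N)s1)c1ccc(-c2ccc3cccc(F)c3c2)[nH]c1=O` gives 0.178 h.

Compound 3 stands lowest of the two numbers shown, with compound 1 well above it, while compound 2 sits at the limit of > 3 h in this assay, at which 1 of the 3 values shown sits. Among the compounds with values here, the only measured step, an at least 1.1-fold higher number from compound 1 to compound 2 (0.04 log units; that floor lies within the scatter), concerns methyl in place of hydrogen on an aromatic carbon and stays within the scatter. Compound 4 `Cc1c[nH]c(C(c2ccc(-c3ccc4cccc(F)c4c3)[nH]c2=O)C(C)C)n1` differs from compound 3 by 4-methyl-1H-imidazol-2-yl in place of 2-amino-1,3-thiazol-5-yl on a saturated chain carbon bound to an aromatic carbon and a saturated chain carbon. Within the data shown here, no measured step touches this exchange, so the data give no direction for it. Compound 4 is therefore expected to stay near compound 3, with an estimated step of a 1.7-fold higher number from compound 3 to compound 4 (0.23 log units; within the scatter). The estimate for compound 4 in this assay is 0.3 h, between 0.1 h and 1 h.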

Compound 4, half-life: 0.09 h
Compound 4: middle estimate off by 3.3-fold (0.52 log units), on the high side; measured number below the stated range.
By their numbers in this assay, from the lowest: compounds 4 and 3 (each within the scatter of the next); then compound 1. At a limit, above all of these: compound 2.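

In this assay the exchange to 4-methyl-1H-imidazol-2-yl from 2-amino-1,3-thiazol-5-yl on this saturated chain carbon gives a 2.0-fold lower number from compound 3 to compound 4 (0.30 log units; within the scatter). At this place, then, one five-membered aromatic ring with 2 hetero atoms replaced another without a change that can be told from the scatter. The data shown offer no measured reason for this step. From the compounds shown here alone, whether a carboxylic acid or an amine at the same place would shift the half-life beyond the scatter stays open. So does whether this exchange would read the same on the core of compound 1.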